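Moving one group on a shared core: compound 2 to compound 4

The source may report more compounds than this note shows. Statements on the series, on what has been measured and on what is new or still open speak of the compounds shown alone.

Measured in an ADME assay on HepG2 2.2.15 cells (Homo sapiens) for cytotoxicity, read by MTT assay; a higher number here means that more compound is tolerated, a lower number that less compound is tolerated:
- Compound 1 `C=C1CC[C@@H]2[C@](C)(COC(=O)c3cccnc3)[C@H](OC(=O)c3cccnc3)CC[C@@]2(C)[C@@H]1/C=C/C1=CCOC1=O`: > 1910000 nM (a limit of the assay)
- Compound 2 `C=C1CC[C@@H]2[C@](C)(COC(C)=O)[C@H](OC(C)=O)CC[C@@]2(C)[C@@H]1/C=C/C1=CCOC1=O`: 757000 nM
- Compound 3 `C=C1CC[C@@H]2[C@](C)(COC(=O)/C=C/c3cc(OC)c(OC)c(OC)c3)[C@H](O)CC[C@@]2(C)[C@@H]1C/C=C1\C=COC1=O`: 325000 nM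

Compound 1 gives only a limit, > 1910000 nM. Of the two true numbers, compound 2 has the higher at 757000 nM, and compound 3 lies lower at 325000 nM, a gap beyond the usual scatter.

Compound 4 `C=C1CC[C@@H]2[C@](C)(COC(C)=O)[C@H](OC(C)=O)CC[C@@]2(C)[C@@H]1C/C=C1\C=COC1=O` has the same atoms as compound 2, joined differently. One group gives way to another on a saturated ring carbon of a six-membered non-aromatic ring of carbon only: a group of 8 heavy atoms (6 carbon, 2 oxygen; one five-membered non-aromatic ring with 1 hetero atom) in place of a group of 8 heavy atoms (6 carbon, 2 oxygen; one five-membered non-aromatic ring with 1 hetero atom), on a saturated ring carbon.

Among the measured compounds shown here, no two measured compounds differ in just one place, so no measured step can serve as a guide in this assay. The entering group also occurs in compound 3, which shows 325000 nM but differs elsewhere too, so only a slight fall is expected. The estimated change, a 1.5-fold lower number from compound 2 to compound 4 (0.18 log units; within the scatter), stays within the scatter. Compound 4 is estimated at 500000 nM, with an expected range of 200000 nM to 1200000 nM.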

Compound 4, half-maximal cytotoxic concentration: 297000 nM
The estimate for compound 4 lay 1.7-fold (0.23 log units) above the measured number; the measured number falls inside the stated range.
By their numbers in this assay, from the lowest: compounds 4 and 3 (each within the scatter of the next); then compound 2. At a limit, above all of these: compound 1.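

With the rest of the shared core unchanged, swapping one group for its rearranged counterpart on the saturated ring carbon gives a 2.5-fold lower number from compound 2 to compound 4 (0.41 log units; beyond the scatter) in this assay. This is the first comparison among these compounds in which only one place differs, so it links a change at this position to less compound being tolerated. The leaving and entering groups have the same atoms and the same counts of double bonds, donors and acceptors, so the way those atoms are joined is the only difference, but no measurement shown explains why it moves the number.

From the compounds shown here alone, compound 1 stands at > 1910000 nM, a limit of the assay, so it remains open whether the same swap would give a similar step on the core of compound 1. Also open, going by these compounds, is how this position would respond to a group of a different kind, such as a chain ending in an amine or a carboxylic acid.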